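This account rests on a few compounds, and the source may have more. Where it says the series, first, only, none or still open, it means among the compounds named here.

Three compounds share one core and differ only in the group on a saturated ring carbon. Compound 1 `Cc1nccn1-c1ccc(COc2cc(F)cc(C3(S(C)(=O)=O)CCOCC3)c2)cc1` carries methylsulfonyl there. In an assay on blood for inhibition of Polyunsaturated fatty acid 5-lipoxygenase (Homo sapiens) (a lower number here means a stronger inhibitor, a higher number a weaker inhibitor), compound 1 gives only a limit of the assay, > 1000 nM, which is the limit of > 1000 nM in this assay, at which 1 of the 3 values shown sits. Compound 2 `Cc1nccn1-c1ccc(COc2cc(F)cc(C3(C(=O)N(C)C)CCOCC3)c2)cc1`, with dimethylcarbamoyl in that place, gives 810 nM in this assay. Compound 3 `CCOC(=O)C1(c2cc(F)cc(OCc3ccc(-n4ccnc4C)cc3)c2)CCOCC1`, with ethoxycarbonyl there, gives 200 nM in this assay and so holds the lowest of the two numbers; the step of a 4.1-fold lower number from compound 2 to compound 3 (0.61 log units; beyond the scatter) lies beyond the scatter, as does an at least 5.0-fold lower number from compound 1 to compound 3 (0.69 log units; beyond the scatter).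

Compound 4 `Cc1nccn1-c1ccc(COc2cc(F)cc(C3([S+](C)[O-])CCOCC3)c2)cc1` has not yet been measured. It differs from compound 3 in that (a group of 3 heavy atoms (1 carbon, 1 oxygen, 1 sulfur; no ring) in place of a group of 5 heavy atoms (3 carbon, 2 oxygen; no ring), on a saturated ring carbon). The entering group resembles the sulfur-bearing group of compound 1 more than the carbonyl-bearing groups of compound 2 and compound 3. Given an at least 5.0-fold lower number from compound 1 to compound 3 (0.69 log units; beyond the scatter) and a 4.1-fold lower number from compound 2 to compound 3 (0.61 log units; beyond the scatter), a higher number is expected for compound 4 in this assay, estimated at 800 nM with a range of 300 nM to 2500 nM, a step of a 4.0-fold higher number from compound 3 to compound 4 (0.60 log units; beyond the scatter).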

Compound 4, half-maximal inhibitory concentration: > 1000 nM
Compound 4: no number, only a limit (the forecaster's own chance of this, stated with the estimate: 30%); middle value at least 1.2-fold (0.09 log units) away from the limit.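

In this assay, replacing the ethoxycarbonyl of the earlier best compound with this smaller sulfur-bearing group gives an at least 5.0-fold higher number from compound 3 to compound 4 (0.69 log units; beyond the scatter), so the low number at this saturated ring carbon did not survive a second sulfur-bearing group. Against the dimethylcarbamoyl group, the reading is only an at least 1.2-fold higher number from compound 2 to compound 4 (0.09 log units; that floor lies within the scatter), so no order can be claimed for that pair. With both sulfur-bearing groups now giving only a limit, ethoxycarbonyl remains the sole group shown here that reaches the lowest number, while compound 2 keeps a measured value: the limit of > 1000 nM in this assay, at which 2 of the 4 values shown sit.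

On these data alone, how far compound 1 and compound 4 lie beyond that limit stays unknown, and the step between them cannot be read. The compounds shown also leave open how a carboxylic acid, a primary amine or a longer ester chain such as butoxycarbonyl would read at this place.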